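Halogen change on the shared core: outlook for compound 3

A few compounds are considered here, and "the series" means these few. Any claim that something is new, unique, unknown or untested is made for them only; others in the source may bear on it.

Measured so far:
compound 1 `O=C(CNc1ccccc1F)N[C@H]1CCOC1=O`, in a functional assay on MGC-803 cells (Homo sapiens) for antiproliferative activity, read by MTT assay, with a stated time of 72 h (on this read-out lower numbers stand for stronger inhibition and higher numbers for weaker inhibition), compound 1 gives > 64000 nM
compound 2 `O=C(CNc1ccccc1)N[C@H]1CCOC1=O`, in this assay compound 2 gives > 64000 nM.

For compound 1 the value in this assay is only a limit, > 64000 nM. For compound 2 the value in this assay is likewise only a limit, > 64000 nM. The change between them, hydrogen in place of fluoro on an aromatic carbon, is a step that the two limits leave unreadable from compound 1 to compound 2. Among the compounds with values here, compound 2 therefore stands at the limit of this assay, and the limit of > 64000 nM in this assay, at which 2 of the 2 values shown sit, shows that every value known so far sits there; no ranking within the pair is possible.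

Compound 3 `O=C(CNc1ccccc1Cl)N[C@H]1CCOC1=O` is not yet measured. Relative to compound 2 the change is chloro in place of hydrogen on an aromatic carbon. Within the data shown here, the only step that bears on it, a step that the two limits leave unreadable from compound 1 to compound 2, is unreadable, so no size or direction can be taken from it for this assay; the one thing the numbers say is that both halogen-free and fluoro-bearing members fall at the limit. The expectation for compound 3 in this assay is that it too most likely returns a limit rather than a number. The estimate for compound 3 in this assay is 100000 nM, with a range from 30000 nM to 300000 nM. The expected step is a step that the limit leaves unreadable from compound 2 to compound 3, not beyond the scatter.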

Compound 3, half-maximal inhibitory concentration: > 64000 nM
Compound 3 gave a limit, no number (the forecaster's own chance of this, stated with the estimate: 85%); the middle value lies beyond the limit too.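

Compound 3 gives > 64000 nM in this assay, a limit and not a number, so no new step can be read among compound 1, compound 2 and compound 3: the limit of > 64000 nM in this assay, at which 3 of the 3 values shown sit.

The compounds shown leave open how these three rank and whether any change on the shared core gives a readable value in this assay.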